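From Fluorophenyl to Methylsulfanylphenyl: Expected Agonist Efficacy

The compounds below may be only part of what the source reports. "The series", "measured", "known", "first", "only" and "open" are said of these compounds alone.

Measured so far:
Compound 1 `O=C(CN1CCC(c2cccc[n+]2[O-])CC1)Nc1cccc(F)c1` gives 70% in a functional assay on HEK293 cells for agonist activity at D(4) dopamine receptor (Homo sapiens), read by FLIPR; a higher number here means a larger maximal response, a lower number a smaller maximal response.
Compound 2 `O=C(CN1CCC(c2cccc[n+]2[O-])CC1)Nc1ccc(F)cc1` gives 71% in this assay.

Compound 2 has the nearest neighbour compound 1, and the step of a number 1 percentage points higher from compound 1 to compound 2 (within the scatter) lies within the scatter, so the two numbers cannot be told apart. Compound 3 `CSc1cccc(NC(=O)CN2CCC(c3cccc[n+]3[O-])CC2)c1` differs from compound 2 by 3-(methylsulfanyl)phenyl in place of 4-fluorophenyl on an amide-type nitrogen. Among the compounds with values here, the only measured step moves a fluorine around the ring, and it was a number 1 percentage points higher from compound 1 to compound 2 (within the scatter); no measured step brings in a methylsulfanyl group. Compound 3 is therefore expected to show a step of a number 1 percentage points lower from compound 2 to compound 3 (within the scatter), none beyond the scatter. For compound 3 the estimated value is 70%, ranging from 55% to 85%.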

Compound 3, largest response reached (reported as efficacy), in percent of the reference or control that the assay uses: 56%
For compound 3 the middle estimate is 14 percentage points above the measured one; the range from low to high includes it.
By their numbers in this assay, from the lowest: compound 3; then compounds 1 and 2 (each within the scatter of the next).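

In this assay, the group on the amide-type nitrogen does matter: moving the fluorine changed nothing readable, but methylsulfanyl in place of fluoro on an aromatic carbon gives a number 14 percentage points lower from compound 1 to compound 3 (beyond the scatter) with the rest of the molecule unchanged. The comparison with the other fluorinated compound, a number 15 percentage points lower from compound 2 to compound 3 (beyond the scatter), also lies beyond the scatter, so the fall does not depend on which fluorophenyl is the starting point. From the compounds shown here alone, whether a methoxy group or an amine in place of methylsulfanyl would keep the response of the fluorophenyl compounds remains open. Why the response falls also stays open, as nothing here bears on it.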